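Replacing 4-methylphenyl with 3-nitrophenyl in compound 3

The source may hold more compounds than are shown below. What is called first, only, known or untested is meant among the compounds shown, and "the series" means these compounds.

In a functional assay on A549 cells (Homo sapiens) for antiproliferative activity, read by MTT assay, with a stated time of 72 h (a lower number here means a stronger inhibitor, a higher number a weaker inhibitor), compound 1 (`Cc1ccc(-c2noc(CCCCCCC(=O)NO)n2)cc1`) gives 5810 nM and compound 2 (`O=C(CCCCCCc1nc(-c2ccc(F)cc2)no1)NO`) gives 5770 nM. Compound 3 (`Cc1ccc(-c2noc(CCCCCCC(=O)Nc3ccccc3N)n2)cc1`) gives 9170 nM, which lies within the scatter of both other values. The unmeasured compound 4 (`Nc1ccccc1NC(=O)CCCCCCc1nc(-c2cccc([N+](=O)[O-])c2)no1`) carries 3-nitrophenyl in place of the 4-methylphenyl of compound 3, on an aromatic carbon of a five-membered aromatic ring with 2 nitrogen and 1 oxygen: 3-nitrophenyl in place of 4-methylphenyl on an aromatic carbon. One measured step alters the group that leaves here: a 1.0-fold lower number from compound 1 to compound 2 (0.00 log units; within the scatter), with fluoro in place of methyl on an aromatic carbon. The other, a 1.6-fold higher number from compound 1 to compound 3 (0.20 log units; within the scatter), has 2-aminophenyl in place of hydroxy on an amide-type nitrogen and shows the same result on a different part of the structure. Going by the values given here, no measured compound carries a nitro group, so the evidence is thin. Resting on a 1.0-fold lower number from compound 1 to compound 2 (0.00 log units; within the scatter), no step beyond the scatter is expected in this assay, in either direction. The estimated change is a 1.1-fold lower number from compound 3 to compound 4 (0.03 log units; within the scatter). The expected value for compound 4 is 8500 nM, with an estimated range of 3000 nM to 24000 nM.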

Compound 4, half-maximal inhibitory concentration: 20200 nM
Compound 4: the middle estimate sits 2.4-fold (0.38 log units) below what was measured, within the range that was stated.
By their numbers in this assay, from the lowest: compounds 2, 1 and 3 (each within the scatter of the next); then compound 4.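

In this assay, 3-nitrophenyl in place of 4-methylphenyl gives a 2.2-fold higher number from compound 3 to compound 4 (0.34 log units; beyond the scatter), a modest step but the first one beyond the scatter among these compounds. The earlier change on this aryl group, fluoro in place of methyl, gave a 1.0-fold lower number from compound 1 to compound 2 (0.00 log units; within the scatter), so only now does the group on this aromatic carbon of the five-membered ring show that it can move the number. Nothing measured here bears on why this step occurs.

The compounds shown do not separate the nitro group from its place on the phenyl ring, which 3-methylphenyl or 4-nitrophenyl on the same scaffold could address. As far as these compounds go, it also stays open whether 3-nitrophenyl would give a similar step with hydroxy rather than 2-aminophenyl on the amide-type nitrogen.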